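Stereochemical inversion on a pyrazolopyrimidine alkyne amide series

A few compounds are considered here, and "the series" means these few. Any claim that something is new, unique, unknown or untested is made for them only; others in the source may bear on it.

Compound 1 `Cc1ccc(NC(=O)c2cccc(C(F)(F)F)c2)cc1C#Cc1nn(C[C@H](C)CO)c2ncnc(N)c12` gives 10 nM in a functional assay on MDA-MB-435 cells (Homo sapiens) for antiproliferative activity, read by MTT assay, with a stated time of 72 h; on this read-out higher numbers stand for weaker inhibition and lower numbers for stronger inhibition. Compound 2 `Cc1ccc(NC(=O)c2ccc(C)c(C(F)(F)F)c2)cc1C#Cc1nn(C[C@H](C)CO)c2ncnc(N)c12` gives 61 nM. Compound 3 `Cc1ccc(NC(=O)c2ccc(Cl)c(C(F)(F)F)c2)cc1C#Cc1nn(C[C@@H](C)CO)c2ncnc(N)c12` gives 319 nM.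

Compound 3 gives the highest number of the three in this assay, standing well apart from compound 2 and still further from compound 1. Among the compounds with values here, the only single-place step among the measured compounds is a 6.1-fold higher number from compound 1 to compound 2 (0.79 log units; beyond the scatter), and it concerns a substituent on the aromatic ring, not the chain stereocentre.

Compound 4 `Cc1ccc(NC(=O)c2ccc(Cl)c(C(F)(F)F)c2)cc1C#Cc1nn(C[C@H](C)CO)c2ncnc(N)c12` differs from compound 3 in that (the two compounds have the same atoms and bonds and differ only in configuration as drawn: 1 of 1 stereo elements differ; a stereocentre at a saturated chain carbon is drawn R in compound 3 and S in compound 4). Within the data shown here, no measured step bears on this change: compound 1 and compound 2 both carry the configuration of compound 4, but each also differs from compound 3 in a second place, so their values show only that this configuration is compatible with low numbers. A direction cannot be read from the data. The step from compound 3 to compound 4 is therefore expected to be a 2.7-fold lower number from compound 3 to compound 4 (0.42 log units; beyond the scatter), and compound 4 is estimated at 120 nM, within 25 nM to 600 nM.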

Compound 4, half-maximal inhibitory concentration: 323 nM
For compound 4 the middle estimate is 2.7-fold (0.43 log units) below the measured one; measured number inside the range.
By their numbers in this assay, from the lowest: compound 1; then compound 2; then compounds 3 and 4 (each within the scatter of the next).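

In this assay, changing the saturated chain stereocentre from R to S gives a 1.0-fold higher number from compound 3 to compound 4 (0.01 log units; within the scatter), so with the chloro group on the aromatic ring, the drawn configuration at this position has no effect beyond the scatter, and this reading can be tied to the stereocentre alone because of one fact: the fact that compounds 3 and 4 differ only in the configuration as drawn. With the configuration matched, the aromatic changes can also be read: chloro in place of methyl gives a 5.3-fold higher number from compound 2 to compound 4 (0.72 log units; beyond the scatter), and chloro in place of hydrogen gives a 32-fold higher number from compound 1 to compound 4 (1.51 log units; beyond the scatter). Among these four compounds, the higher numbers therefore go with the chloro group and not with the chain configuration.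

The compounds shown leave open whether configuration matters as little with hydrogen or methyl on that aromatic carbon. They also leave open how a bromo group in place of chloro, or an amine in place of the chain hydroxyl, would fare.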